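The compounds below may be only part of what the source reports. "The series", "measured", "known", "first", "only" and "open" are said of these compounds alone.

Measured compounds in the series:
Compound 1, `O=S(=O)(NCCCNCc1ccc(Cl)cc1)c1cc(C(F)(F)F)cc(C(F)(F)F)c1`, gives 1800 nM.
Compound 2, `COc1ccc(CNCCCNS(=O)(=O)c2cc(C(F)(F)F)cc(C(F)(F)F)c2)cc1OC`, gives 3800 nM.
Compound 3, `CC(C)(C)c1ccc(CNCCCNS(=O)(=O)c2cc(C(F)(F)F)cc(C(F)(F)F)c2)cc1`, gives 2900 nM.

All three share the same core and differ only in the aryl group on the saturated chain carbon bound to the amine nitrogen. In a functional assay on A2780 cells (Homo sapiens) for inhibition, read by MTT assay, with a stated time of 72 h (a higher number here means a weaker inhibitor of growth, a lower number a stronger inhibitor of growth), compound 3 holds the second highest of the three numbers; its nearest neighbour is compound 2, with a 1.3-fold lower number from compound 2 to compound 3 (0.12 log units; within the scatter), and its furthest is compound 1, with a 1.6-fold higher number from compound 1 to compound 3 (0.21 log units; within the scatter). Going by the values given here, only one step in the set reaches beyond the scatter, a 2.1-fold higher number from compound 1 to compound 2 (0.32 log units; beyond the scatter), and that one is modest.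

Compound 4, `O=S(=O)(NCCCNCc1ccc(-c2ccccc2)cc1)c1cc(C(F)(F)F)cc(C(F)(F)F)c1`, differs from compound 3 in one place: phenyl in place of tert-butyl on an aromatic carbon. The step most directly bearing on this is the exchange at the same aromatic carbon from compound 1 to compound 3, which stayed within the scatter, and the exchange from compound 2 to compound 3 likewise stayed within the scatter. Variation at this position has so far moved this assay little, so the expected step of a 1.1-fold lower number from compound 3 to compound 4 (0.05 log units; within the scatter) is none beyond the scatter, in either direction. Compound 4 is therefore estimated at 2600 nM, with a range from 1000 nM to 6500 nM.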

Compound 4, concentration for 50% growth inhibition: 2600 nM
For compound 4 middle estimate and measured number coincide at the digits printed; measured number inside the range.
By their numbers in this assay, from the lowest: compounds 1, 4, 3 and 2 (each within the scatter of the next, the first and the last beyond it).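

In this assay this aromatic carbon, para to a large group, now carries one six-membered aromatic ring of carbon only, and phenyl in place of tert-butyl gives a 1.1-fold lower number from compound 3 to compound 4 (0.05 log units; within the scatter) with the number staying inside the scatter although a group with no ring and 4 heavy atoms gives way to a ring with 6. Phenyl in place of chloro at the same carbon gives a 1.4-fold higher number from compound 1 to compound 4 (0.16 log units; within the scatter) and also stays inside the scatter, so in this series chloro, tert-butyl and phenyl at this carbon cannot be told apart in this assay on these numbers. Nothing at hand gives a measured reason for this flat response.

Open, from the compounds shown here alone, is whether a carboxylic acid or an amine at this aromatic carbon would keep the number inside the same narrow band that chloro, tert-butyl and phenyl occupy. Also open is how far a longer chain in the shared core would move the number, since all the compounds shown vary only in the aryl group.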